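Switching the amide aryl group in a weak phenyl-series analogue

The source may report more compounds than this note shows. Statements on the series, on what has been measured and on what is new or still open speak of the compounds shown alone.

Compound 2 `COc1ccc(NC(=O)CN2CCN(c3nnc(Cc4ccccc4)c4ccccc34)CC2)cc1OC` stands highest of the three numbers shown: in a functional assay on MDA-MB-231 cells (Homo sapiens) for cytotoxicity, read by MTT assay, with a stated time of 72 h (on this read-out lower numbers stand for stronger inhibition and higher numbers for weaker inhibition), compound 2 gives 32200 nM, whereas compound 1 `Cc1cccc(Cl)c1NC(=O)CN1CCN(c2nnc(Cc3ccncc3)c3ccccc23)CC1` gives 2670 nM and compound 3 `COc1ccc(NC(=O)CN2CCN(c3nnc(Cc4ccncc4)c4ccccc34)CC2)cc1OC` gives 100 nM. Compound 4 `O=C(CN1CCN(c2nnc(Cc3ccccc3)c3ccccc23)CC1)Nc1cccc(F)c1` is not yet measured; it differs from compound 2 in one place (3-fluorophenyl in place of 3,4-dimethoxyphenyl on an amide-type nitrogen).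

Among the compounds with values here, only one measured step touches the amide-type nitrogen: a 27-fold lower number from compound 1 to compound 3 (1.43 log units; beyond the scatter), a large move within the pyridin-4-yl series. The other step, a 320-fold lower number from compound 2 to compound 3 (2.51 log units; beyond the scatter), changes the saturated chain carbon instead and does not bear on this exchange. Within the data shown here, no measured pair shows 3-fluorophenyl at all, so the direction is uncertain; since leaving 3,4-dimethoxyphenyl from compound 3 for another aryl gave compound 1 a higher number, a move toward higher numbers or none beyond the scatter is expected for compound 4, expressed as a 1.2-fold higher number from compound 2 to compound 4 (0.09 log units; within the scatter). Compound 4 is therefore estimated at 40000 nM, with a range from 8000 nM to 150000 nM.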

Compound 4, half-maximal inhibitory concentration: 3730 nM
Compound 4: middle estimate off by 11-fold (1.03 log units), on the high side, and the stated range ends above it.
By their numbers in this assay, from the lowest: compound 3; then compounds 1 and 4 (each within the scatter of the next); then compound 2.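

In this assay the amide-type nitrogen proves to matter in the phenyl series as well: there is an 8.6-fold lower number from compound 2 to compound 4 (0.94 log units; beyond the scatter), a modest move, made by leaving 3,4-dimethoxyphenyl. In the pyridin-4-yl series the same group goes with the lower number, with a 27-fold lower number from compound 1 to compound 3 (1.43 log units; beyond the scatter), so 3,4-dimethoxyphenyl is not the better amide aryl group in both series, although the two steps have different partners and are not the same exchange. Nothing available accounts for this difference between the series.

Going by these compounds, it remains open whether 3-fluorophenyl would lower the number with pyridin-4-yl on the chain carbon as it does with phenyl there. On these data alone, how a 3-chlorophenyl or a 3-aminophenyl group on the same nitrogen would compare also stays open.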